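Swapping 4-cyanophenyl for pyridin-4-yl on compound 1

A few compounds are considered here, and "the series" means these few. Any claim that something is new, unique, unknown or untested is made for them only; others in the source may bear on it.

- Compound 1 `C[C@H](Nc1ncnc2[nH]cnc12)c1nn(-c2ccc(C#N)cc2)c2cc(F)ccc12` gives 13500 nM in a functional assay on Hep 3B2 cells (Homo sapiens) for inhibition, read by sulforhodamine B assay, with a stated time of 72 h; on this read-out lower numbers stand for stronger inhibition and higher numbers for weaker inhibition
- Compound 2 `C[C@H](Nc1nc(N)nc(N)c1C#N)c1nn(-c2cccc(S(C)(=O)=O)c2)c2cc(Cl)ccc12` gives 5110 nM in this assay

Compound 1 holds the higher of the two numbers, and compound 2 stands lower by more than the usual scatter. The two compounds differ in more than one place, so their gap does not isolate any single change.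

Compound 3 `C[C@H](Nc1ncnc2[nH]cnc12)c1nn(-c2ccncc2)c2cc(F)ccc12` is not yet measured. It carries pyridin-4-yl in place of 4-cyanophenyl on an aromatic nitrogen of a five-membered aromatic ring with 2 nitrogen (pyridin-4-yl in place of 4-cyanophenyl on an aromatic nitrogen). Among the compounds with values here, no measured pair shows this change, so the data offer no direct guide. In this assay no step beyond the scatter is expected, and the range is kept wide. The expected step is small (a 1.1-fold lower number from compound 1 to compound 3 (0.05 log units; within the scatter)). For compound 3 the estimated value is 12000 nM (expected range 4000 nM to 35000 nM).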

Compound 3, half-maximal inhibitory concentration: 21400 nM
Compound 3: the middle estimate sits 1.8-fold (0.25 log units) below what was measured; the measured number falls inside the stated range.
By their numbers in this assay, from the lowest: compound 2; then compounds 1 and 3 (each within the scatter of the next).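

Replacing 4-cyanophenyl with pyridin-4-yl on the aromatic nitrogen gives a 1.6-fold higher number from compound 1 to compound 3 (0.20 log units; within the scatter) in this assay and does not separate the two groups on this read-out. In this one pair, on the core of compound 1, the nitrile can be given up and a ring nitrogen taken into the six-membered aromatic ring without a step beyond the scatter. Nothing available speaks to a cause for this result.

Still open, on these data alone, is whether this tolerance holds for other groups at this position, such as a phenyl ring bearing an amine or a carboxylic acid, or a plain methyl group in place of the ring. Also open is which of the several differences between compound 1 and compound 2 accounts for the gap between them.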